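The compounds below may be only part of what the source reports. "The series", "measured", "known", "first", "only" and "open" are said of these compounds alone.

Measured compounds:
compound 1 `Fc1ccc(/C=N/NC(=S)Nc2cccc3ccccc23)cc1Cl`: 51.3 ug/mL
compound 2 `Fc1cc(F)c(/C=N/NC(=S)Nc2cccc3ccccc23)c(F)c1`: > 500 ug/mL

In a functional assay on A549 cells (Homo sapiens) for cytotoxicity, read by XTT assay, with a stated time of 24 h (on this read-out higher numbers stand for weaker inhibition and lower numbers for stronger inhibition), compound 1 gives 51.3 ug/mL. Compound 2 reaches only > 500 ug/mL, which is a limit of the assay and not a number. Compound 2 thus stands at the limit of > 500 ug/mL in this assay, at which 1 of the 2 values shown sits; it is the only one of the two measured compounds that does so, while compound 1 has a number inside the measured range. Compound 3 `Fc1ccc(/C=N/NC(=S)Nc2cccc3ccccc23)c(F)c1` has not yet been measured in this assay. The change from compound 2 to compound 3 is hydrogen in place of fluoro on an aromatic carbon. Among the compounds with values here, no step between measured compounds that differ in one place is known, so the expected size of this step rests only on the two values shown. With compound 2 at a limit, the step to compound 3 is expected to move toward a measurable value, in the direction of stronger inhibition, but its size is uncertain and may not exceed the scatter. Compound 3 is expected to give about 250 ug/mL, within a range from 80 ug/mL to 800 ug/mL. That estimate corresponds to an expected step of an at least 2.0-fold lower number from compound 2 to compound 3 (0.30 log units; that floor lies within the scatter) in this assay.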

Compound 3, half-maximal inhibitory concentration: 31.3 ug/mL
For compound 3 the middle estimate is 8.0-fold (0.90 log units) above the measured one; the measured number lies below the stated range.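

In this assay, hydrogen in place of fluoro on an aromatic carbon, ortho to a large group and meta to two fluoro groups, gives an at least 15-fold lower number from compound 2 to compound 3 (1.20 log units; beyond the scatter). Within the data shown here, this is the first step read at this position, and it shows that this single fluoro group separates a compound with a measured number from one without. The value of compound 2 is a limit of the assay and not a number, so the step has a floor and no exact size: the limit of > 500 ug/mL in this assay, at which 1 of the 3 values shown sits. 2,4-Difluorophenyl in place of 3-chloro-4-fluorophenyl gives a 1.6-fold lower number from compound 1 to compound 3 (0.21 log units; within the scatter), so among these three compounds, only the step that adds or removes this fluoro group goes beyond the scatter.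

The compounds shown leave open whether a chloro, methoxy or amino group at this position would read like fluoro or like hydrogen in this assay. They also leave open how this position behaves on the core of compound 1, which carries a different pattern of halogens, and what true number lies behind the limit of compound 2.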